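Adding Bromo to the Benzamide Ring of Compound 1

The source may hold more compounds than are shown below. What is called first, only, known or untested is meant among the compounds shown, and "the series" means these compounds.

Compound 1 `O=C(Nc1cccc(-c2oc3cc(-c4ccc(F)cc4)ccc3c(=O)c2O)c1)c1ccccc1F` gives 4410 nM in a functional assay on A549 cells (Homo sapiens) for antiproliferative activity, read by CCK-8 assay, with a stated time of 72 h; a lower number here means a stronger inhibitor, a higher number a weaker inhibitor.
Compound 2 `COc1cccc(C(=O)Nc2cccc(-c3oc4cc(-c5ccc(F)cc5)ccc4c(=O)c3O)c2)c1` gives 10800 nM.
Compound 3 `CCc1ccc(C(=O)Nc2cccc(-c3oc4cc(-c5ccc(F)cc5)ccc4c(=O)c3O)c2)cc1` gives 18500 nM.

All three share one core and differ only in the ring attached to the carbonyl carbon of the amide. Compound 1 stands lowest of the three numbers, so it is the strongest inhibitor among them. The two steps away from it both go up: a 2.4-fold higher number from compound 1 to compound 2 (0.39 log units; beyond the scatter), and a 4.2-fold higher number from compound 1 to compound 3 (0.62 log units; beyond the scatter). Between the other two the gap is smaller: a 1.7-fold higher number from compound 2 to compound 3 (0.23 log units; within the scatter).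

Compound 4 `O=C(Nc1cccc(-c2oc3cc(-c4ccc(F)cc4)ccc3c(=O)c2O)c1)c1ccc(Br)cc1F` keeps the 2-fluorophenyl of compound 1 and differs from it by bromo in place of hydrogen on an aromatic carbon. The measured steps each swap the whole ring for a different one, and each raises the number, so they show that this ring is sensitive to change; none of them adds a single bromo while keeping the fluoro, so they bear on the present step only loosely. A small step is therefore expected, most likely toward a somewhat higher number, but one that may well stay within the scatter.

Compound 4 is expected to give about 5500 nM, in a range from 2000 nM to 14000 nM. The expected step is a 1.2-fold higher number from compound 1 to compound 4 (0.10 log units; within the scatter).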

Compound 4, half-maximal inhibitory concentration: 46100 nM
For compound 4 the middle estimate is 8.4-fold (0.92 log units) below the measured one; measured number outside the range, above it.
By their numbers in this assay, from the lowest: compound 1; then compounds 2 and 3 (each within the scatter of the next); then compound 4.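

In this assay, a single bromo in place of hydrogen, para to a large group and meta to the fluoro group, produces a 10-fold higher number from compound 1 to compound 4 (1.02 log units; beyond the scatter), a larger step than either whole-ring swap away from compound 1 showed. The 4-bromo-2-fluorophenyl ring also separates compound 4 from the compounds carrying other rings, with a 2.5-fold higher number from compound 3 to compound 4 (0.40 log units; beyond the scatter) and a 4.3-fold higher number from compound 2 to compound 4 (0.63 log units; beyond the scatter), which makes compound 4 the weakest inhibitor of the four. Keeping the 2-fluorophenyl ring therefore does not by itself keep the number low, and among these compounds a change of just one heavy atom on this ring moves the number more than replacing the ring does.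

Nothing available here explains why this one atom has so large an effect. On these data alone, it also remains open whether the loss belongs to bromo itself or would follow any group at this place, such as chloro, methyl or an amine, and whether bromo would have the same effect on a ring without the fluoro group.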